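Swapping Fluoro for Hydroxy on Compound 3

This account rests on a few compounds, and the source may have more. Where it says the series, first, only, none or still open, it means among the compounds named here.

Compound 3 `CC1CCC(/C=N/c2ccccc2F)=C2NC=C(C(=O)O)C(=O)N21` is one of three related compounds measured in a functional assay on the whole organism with Rattus norvegicus as the target; a higher number here means that more compound is needed for the effect, a lower number that less compound is needed. In this assay compound 3 gives 14.5 umol/kg, the second highest of the three numbers. Compound 1 `CC1CCC(/C=N/c2ccccc2C(=O)O)=C2NC=C(C(=O)O)C(=O)N21` gives 1.11 umol/kg, and compound 2 `CC1CCN2C(=O)C(C(=O)O)=CNC2=C1/C=N/c1ccccc1C(=O)O` gives 100 umol/kg, so compound 3 sits between them. Within the data shown here, the only measured step that changes a single place is a 13-fold higher number from compound 1 to compound 3 (1.12 log units; beyond the scatter), a large rise in the number when carboxy is replaced by fluoro on an aromatic carbon.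

Compound 4 `CC1CCC(/C=N/c2ccccc2O)=C2NC=C(C(=O)O)C(=O)N21` has not yet been measured. It differs from compound 3 by hydroxy in place of fluoro on an aromatic carbon. Hydroxy, like the carboxy of compound 1, brings a hydrogen-bond donor and a hydrogen-bond acceptor where fluoro brought none, so the step to compound 4 is expected to run opposite to the direction seen in a 13-fold higher number from compound 1 to compound 3 (1.12 log units; beyond the scatter), though a single step is a thin basis. A modest fall is therefore expected, a 2.9-fold lower number from compound 3 to compound 4 (0.46 log units; beyond the scatter). Compound 4 is estimated at 5 umol/kg, with a range from 1.5 umol/kg to 15 umol/kg.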

Compound 4, dose for 50% inhibition: 4.11 umol/kg
Compound 4: the middle estimate sits 1.2-fold (0.09 log units) above what was measured, and the stated range covers the measured number.
By their numbers in this assay, from the lowest: compound 1; then compound 4; then compound 3; then compound 2.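

On this aromatic carbon, a third group can now be compared in this assay, and hydroxy in place of fluoro gives a 3.5-fold lower number from compound 3 to compound 4 (0.55 log units; beyond the scatter). Hydroxy does not take the number all the way back to that of the carboxy compound, as hydroxy in place of carboxy gives a 3.7-fold higher number from compound 1 to compound 4 (0.57 log units; beyond the scatter), so the three groups at this one place give three separate readings, with compound 4 in the middle. No measurement here accounts for this order.

An amine, a methoxy group or a chlorine at this place could fall nearer compound 1 or nearer compound 3, and the compounds shown do not settle which. Also open, going by these compounds, is whether the same order of groups would hold with the core arrangement of compound 2.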